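Trading a phenoxymethyl group for trifluoromethoxy

The source may report more compounds than this note shows. Statements on the series, on what has been measured and on what is new or still open speak of the compounds shown alone.

The shared core here is a sulfonamide carrying a pyridylmethyl arm and a benzene ring that bears a variable side group. Compound 1 `CCS(=O)(=O)N(Cc1cccnc1)c1cccc(C(F)c2ccccc2)c1` carries a fluoro(phenyl)methyl group there, and in an assay on isolated protein with metabotropic glutamate receptor 2 (Homo sapiens) as the target (on this read-out lower numbers stand for an effect already at smaller amounts and higher numbers for an effect only at larger amounts of compound), compound 1 gives 180 nM. Compound 2 `CCS(=O)(=O)N(Cc1cccnc1)c1cccc(COc2ccccc2)c1` carries a phenoxymethyl group instead, and in this assay compound 2 gives 160 nM. The step of a 1.1-fold lower number from compound 1 to compound 2 (0.05 log units; within the scatter) shows that the two compounds cannot be told apart on this read-out, so compound 2 sits at the lowest of the two numbers only nominally.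

Compound 3 `CCS(=O)(=O)N(Cc1cccnc1)c1cccc(OC(F)(F)F)c1` is the unmeasured neighbour. The change from compound 2 is trifluoromethoxy in place of phenoxymethyl on an aromatic carbon, so the entering group is smaller and brings no ring. Among the compounds with values here, the one measured step involved swapping one ring-bearing group for another, which says little about removing the ring altogether; no measured step tests that. The expectation is therefore uncertain and leans toward a higher number, a 3.8-fold higher number from compound 2 to compound 3 (0.57 log units; beyond the scatter). Compound 3 is estimated at 600 nM in this assay, with a range from 150 nM to 3000 nM.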

Compound 3, half-maximal effective concentration: 1600 nM
Compound 3: the middle estimate sits 2.7-fold (0.43 log units) below what was measured; measured number inside the range.
By their numbers in this assay, from the lowest: compounds 2 and 1 (each within the scatter of the next); then compound 3.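

Until now this position had only shown one ring-bearing group exchanged for another, with no difference that could be read. In this assay, the ring-free trifluoromethoxy group gives a clear change: a 10-fold higher number from compound 2 to compound 3 (1.00 log units; beyond the scatter) and an 8.9-fold higher number from compound 1 to compound 3 (0.95 log units; beyond the scatter). The position is therefore not indifferent to what it carries: among these compounds, the two side groups with a six-membered aromatic ring sit together at the low end, and trifluoromethoxy stands apart at the high end, with no compound shown going against this. No measurement shown here explains the rise.

Trifluoromethoxy differs from phenoxymethyl in several ways at once, as it has no ring, fewer heavy atoms and three fluorine atoms, so these compounds cannot show which of these differences matters. A plain methoxy group would help separate the fluorine atoms from the other differences, while a ring-free butoxy chain or a benzyl group would help show whether the length of the side group or the ring itself goes with the lower numbers.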